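Chloro to fluoro on the benzyl group: cytotoxicity notes

The source may report more compounds than this note shows. Statements on the series, on what has been measured and on what is new or still open speak of the compounds shown alone.

Compound 1 `O=[N+]([O-])c1cc(Sc2nnnn2C2CCCCC2)cc([N+](=O)[O-])c1` and compound 2 `O=[N+]([O-])c1cc(-c2nnn(Cc3ccc(Cl)cc3)n2)cc([N+](=O)[O-])c1` share a common core. Among the compounds with values here, in an ADME assay on CHO-K1 cells (Cricetulus griseus) for cytotoxicity, read by MTT assay, with a stated time of 24 h (a higher number here means a weaker inhibitor, a lower number a stronger inhibitor), compound 1 gives 153000 nM; compound 2 gives 170000 nM, a number that lies within the usual scatter of the one for compound 1, so the two cannot be told apart here. Compound 3 `O=[N+]([O-])c1cc(-c2nnn(Cc3ccc(F)cc3)n2)cc([N+](=O)[O-])c1` carries fluoro in place of chloro on an aromatic carbon, fluoro in place of chloro on an aromatic carbon. Within the data shown here, no measured pair shows this change; the expected step of a 1.1-fold higher number from compound 2 to compound 3 (0.02 log units; within the scatter) is small, at most a drift toward a higher number, not beyond the scatter. Compound 3 is expected to give 180000 nM in this assay, in the range 90000 nM to 360000 nM.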

Compound 3, half-maximal inhibitory concentration: 35000 nM
Compound 3: middle estimate off by 5.1-fold (0.71 log units), on the high side, and the stated range ends above it.
By their numbers in this assay, from the lowest: compound 3; then compounds 1 and 2 (each within the scatter of the next).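

In this assay, 4-chlorobenzyl to 4-fluorobenzyl gives a 4.9-fold lower number from compound 2 to compound 3 (0.69 log units; beyond the scatter), so exchanging one halogen on the aromatic carbon para to a large group registers in this read-out. The earlier values, within the scatter of each other, gave no sign that this position could move the number. No measurement at hand accounts for the step.

From the compounds shown here alone, how a methoxy group or an amine at this place would read stays open. Going by these compounds, whether the same exchange gives a similar step on another core also stays open.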